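A few compounds are considered here, and "the series" means these few. Any claim that something is new, unique, unknown or untested is made for them only; others in the source may bear on it.

In a functional assay on MCF7 cells (Homo sapiens) for cytotoxicity, read by MTT assay, with stated times of 3 h and 24 h (a lower number here means a stronger inhibitor, a higher number a weaker inhibitor), compound 1 (`COc1ccc(C2=[N+]3C(=Nc4c(-c5ccccc5)c5c(n4[B-]3(F)F)-c3ccc(OC)cc3CC5)C(c3ccccc3)=C2I)cc1`) gives 140 nM, compound 2 (`COc1ccc2c(c1)CCc1c(-c3ccccc3)c3n(c1-2)[B-](F)(F)[N+]1=C(c2ccc(C)cc2)C(I)=C(c2ccccc2)C1=N3`) gives 410 nM, and compound 3 (`COc1ccc2c(c1)CCc1c(-c3ccccc3)c3n(c1-2)[B-](F)(F)[N+]1=C(c2ccc(C)s2)C(I)=C(c2ccccc2)C1=N3`) gives 16600 nM, the highest number of the three. Compound 4 (`COc1ccc2c(c1)CCc1c(-c3ccccc3)c3n(c1-2)[B-](F)(F)[N+]1=C(c2cccs2)C(I)=C(c2ccccc2)C1=N3`) has not yet been measured. It carries hydrogen in place of methyl on an aromatic carbon, so 5-methylthiophen-2-yl becomes thiophen-2-yl (hydrogen in place of methyl on an aromatic carbon). Among the measured compounds shown here, no measured step makes this exact change. Exchanging the whole aryl group gave large steps, a 120-fold higher number from compound 1 to compound 3 (2.07 log units; beyond the scatter) and a 40-fold higher number from compound 2 to compound 3 (1.61 log units; beyond the scatter), whereas the smaller edit gave only a modest one, a 2.9-fold higher number from compound 1 to compound 2 (0.47 log units; beyond the scatter). Taking that modest step as the guide, the expected change is similarly modest and tentatively toward a lower number, a 1.8-fold lower number from compound 3 to compound 4 (0.27 log units; within the scatter). Compound 4 is estimated at 9000 nM, within a range of 1800 nM to 35000 nM.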

Compound 4, half-maximal inhibitory concentration: 750 nM
Compound 4: middle estimate off by 12-fold (1.08 log units), on the high side; the whole stated range lies above it.
By their numbers in this assay, from the lowest: compound 1; then compounds 2 and 4 (each within the scatter of the next); then compound 3.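

In this assay, hydrogen in place of methyl next to the ring sulfur gives a 22-fold lower number from compound 3 to compound 4 (1.35 log units; beyond the scatter), so the removal of one methyl makes a large step. The high number of compound 3 therefore goes with that methyl and not with the thiophen-2-yl group alone: thiophen-2-yl in place of 4-methylphenyl gives a 1.8-fold higher number from compound 2 to compound 4 (0.26 log units; within the scatter), and in place of 4-methoxyphenyl it gives a 5.4-fold higher number from compound 1 to compound 4 (0.73 log units; beyond the scatter). No evidence is available to explain this methyl effect. The compounds shown leave open whether a chlorine atom or an amine on this carbon would behave like hydrogen or like methyl.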